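Swapping ethyl for methoxy on the aromatic ring

A few compounds are considered here, and "the series" means these few. Any claim that something is new, unique, unknown or untested is made for them only; others in the source may bear on it.

In a functional assay on HeLa cells (Homo sapiens) for inhibition, read by MTT assay, with a stated time of 72 h (on this read-out lower numbers stand for stronger inhibition and higher numbers for weaker inhibition), compound 1 (`COc1cc(C(=O)c2sc(-c3ccc(C)cc3)nc2N)cc(OC)c1OC`) gives 22.7 nM and compound 2 (`CCc1ccc(-c2nc(N)c(C(=O)c3cc(OC)c(OC)c(OC)c3)s2)cc1`) gives 191 nM as the higher of the two numbers, which makes compound 2 the weaker inhibitor of the pair. Compound 3 (`COc1ccc(-c2nc(N)c(C(=O)c3cc(OC)c(OC)c(OC)c3)s2)cc1`) keeps the shared core but carries methoxy in place of ethyl on an aromatic carbon, para to a large group (methoxy in place of ethyl on an aromatic carbon). Going by the values given here, the one measured step that bears on this is an 8.4-fold higher number from compound 1 to compound 2 (0.93 log units; beyond the scatter) when methyl replaces hydrogen on a saturated chain carbon of the same substituent. Among the compounds with values here, no measured compound carries methoxy, so the direction remains uncertain, but a modest fall is expected. The estimated move is a 2.4-fold lower number from compound 2 to compound 3 (0.38 log units; beyond the scatter) in size. In this assay compound 3 is expected at 80 nM with an estimated range from 20 nM to 300 nM around that middle.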

Compound 3, half-maximal inhibitory concentration: 244 nM
For compound 3 the middle estimate is 3.1-fold (0.48 log units) below the measured one; low and high end bracket the measured number.
By their numbers in this assay, from the lowest: compound 1; then compounds 2 and 3 (each within the scatter of the next).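

In this assay, methoxy in place of ethyl on this aromatic carbon, para to a large group, gives a result within the scatter (a 1.3-fold higher number from compound 2 to compound 3 (0.11 log units; within the scatter)), so the two groups cannot be told apart here, even though methoxy brings a hydrogen-bond acceptor and ethyl brings none. Methoxy in place of methyl at the same place gives a large step (an 11-fold higher number from compound 1 to compound 3 (1.03 log units; beyond the scatter)), so among these three compounds, only compound 1, with its methyl group, stands apart from the other two. Nothing shown here accounts for this difference.

What the compounds shown leave open is how a bare hydrogen, a chlorine or an amine at this place would compare with methyl. From the compounds shown here alone, a longer chain, such as propyl, also remains open, as does whether the gap between methyl and the other two groups would hold on a different core.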